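This account rests on a few compounds, and the source may have more. Where it says the series, first, only, none or still open, it means among the compounds named here.

Measured compounds:
compound 1 `CCn1c(C)c(C(=O)Nc2ccc(Oc3ncnc4[nH]cc(-c5ccccc5)c34)c(F)c2)c(=O)c2cc(C)ccc21` — in an assay on isolated protein for inhibition of tyrosine-protein kinase receptor UFO (Homo sapiens), read by FRET and Z'-LYTE, with a stated time of 1.5 h (a lower number here means a stronger inhibitor, a higher number a weaker inhibitor), compound 1 gives 150 nM
compound 2 `CCCn1c(C)c(C(=O)Nc2ccc(Oc3ncnc4[nH]cc(-c5ccccc5)c34)c(F)c2)c(=O)c2cc(C)ccc21` — in this assay compound 2 gives 530 nM

For the measured compounds named here, compound 2 holds the higher of the two numbers; its only neighbour is compound 1, separated by a 3.5-fold higher number from compound 1 to compound 2 (0.55 log units; beyond the scatter). Compound 3 `CCCCn1c(C)c(C(=O)Nc2ccc(Oc3ncnc4[nH]cc(-c5ccccc5)c34)c(F)c2)c(=O)c2cc(C)ccc21` carries methyl in place of hydrogen on a saturated chain carbon, three bonds along the chain from an aromatic nitrogen; read one bond further out, propyl to butyl. Going by the values given here, the single step that bears on this change, a 3.5-fold higher number from compound 1 to compound 2 (0.55 log units; beyond the scatter), was modest and upward. For compound 3 the expected step is a 2.3-fold higher number from compound 2 to compound 3 (0.35 log units; beyond the scatter), upward again, with two points giving no guarantee. Compound 3 is estimated at 1200 nM, range 450 nM to 3200 nM.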

Compound 3, half-maximal inhibitory concentration: 480 nM
The estimate for compound 3 lay 2.5-fold (0.40 log units) above the measured number; measured number inside the range.
By their numbers in this assay, from the lowest: compound 1; then compounds 3 and 2 (each within the scatter of the next).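

Extending the chain on the aromatic nitrogen one bond further out does not continue the earlier rise: in this assay, propyl to butyl gives a 1.1-fold lower number from compound 2 to compound 3 (0.04 log units; within the scatter) and sets no order between the two. Ethyl still holds its advantage over the longer butyl chain, with a 3.2-fold higher number from compound 1 to compound 3 (0.51 log units; beyond the scatter) across the whole change. Nothing available accounts for this levelling.

Open, going by these compounds, are methyl or hydrogen on this nitrogen, which would show whether ethyl is a true low point. Also open, on these data alone, is whether a longer chain such as pentyl stays level, or whether an amine or carboxylic acid at the chain end moves the number.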